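Urea and amide acids: liver microsome clearance notes

A few compounds are considered here, and "the series" means these few. Any claim that something is new, unique, unknown or untested is made for them only; others in the source may bear on it.

Measured compounds, with their results in an ADME assay on microsomes from liver (Mus musculus) for metabolic stability, using NADPH, with a stated time of 60 min; on this read-out lower numbers stand for slow clearance and higher numbers for fast clearance:
compound 1 `CC(C)(CC(=O)Nc1ccc(F)c(C(F)(F)F)c1)C(=O)O`; in this assay compound 1 gives < 7 uL/min, which is a limit of the assay and not a number.
compound 2 `O=C(O)CNC(=O)Nc1ccc(F)c(C(F)(F)F)c1`; in this assay compound 2 gives < 7 uL/min, again a limit of the assay rather than a number.

Compound 2 therefore stands at the lower edge of what this assay reports; no number is known for it. The same holds for compound 1, so that (the limit of < 7 uL/min in this assay, at which 2 of the 2 values shown sit). Among the compounds with values here, the one step between measured compounds, a step that the two limits leave unreadable from compound 1 to compound 2, is unreadable because both ends are limits.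

Compound 3 `O=C(Nc1ccc(F)c(C(F)(F)F)c1)NC1(C(=O)O)CCC1` differs from compound 2 by 1-carboxycyclobutyl in place of carboxymethyl on an amide-type nitrogen. Within the data shown here, no measured step involves a 1-carboxycyclobutyl group, and the only measured step gives no size to lean on, so the expectation rests on both measured compounds sitting at the limit. Compound 3 is expected to stay at or near that limit, a step estimated as a step that the limit leaves unreadable from compound 2 to compound 3, not beyond the scatter. The estimate for compound 3 in this assay is 5 uL/min, with a range from 2 uL/min to 12 uL/min.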

Compound 3, intrinsic clearance in a liver preparation (reported as CLH), per the amount of preparation that the assay uses: < 7 uL/min
Compound 3 ended at the assay's limit (the forecaster's own chance of this, stated with the estimate: 70%); the middle value is on the limit's open side.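

In this assay compound 3 gives < 7 uL/min, a limit of the assay and not a number, so no step can be read between compound 2 and compound 3. The compounds shown leave open how fast compound 1, compound 2 and compound 3 are actually cleared, and whether 1-carboxycyclobutyl in place of carboxymethyl makes any difference.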